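Swapping Butyl for Cyclopentyl on a Sulfur

This account rests on a few compounds, and the source may have more. Where it says the series, first, only, none or still open, it means among the compounds named here.

Compound 2 `CCCCSc1nc(C(CC)c2c(F)cccc2Cl)c(C)c(=O)[nH]1` has been tested in an ADME assay on MT4 cells (Homo sapiens) for activation, read by MTT assay (a lower number here means that less compound is tolerated, a higher number that more compound is tolerated), and gives > 3000 nM. That figure is a limit and not a number, so compound 2 has no exact standing. Compound 1 `Cc1c(C(C)c2c(F)cccc2Cl)nc(SC2CCCC2)[nH]c1=O` gives > 15000 nM in this assay, which is also a limit. Within the data shown here, the two limits cannot be ranked, and no measured step links two compounds in this small set.

Compound 3 `CCC(c1nc(SC2CCCC2)[nH]c(=O)c1C)c1c(F)cccc1Cl` follows from compound 2 by one change, cyclopentyl in place of butyl on a sulfur. Among the measured compounds shown here, compound 1 also carries a cyclopentyl on a sulfur, and its limit of > 15000 nM is the only guide, so a modest move toward more compound tolerated is expected. The expected change is a step that the limit leaves unreadable from compound 2 to compound 3. For compound 3 the estimated value is 18000 nM, with an expected range of 4000 nM to 80000 nM.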

Compound 3, half-maximal cytotoxic concentration: > 3000 nM
Compound 3: a limit, no number; the forecaster's own chance of this, stated with the estimate: 65%; the middle value is on the limit's open side.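

Compound 3, like compound 1 and compound 2, gives only a limit in this assay, so neither its step from compound 2 nor its step from compound 1 can be read. The compounds shown leave open whether cyclopentyl in place of butyl on a sulfur changes the tolerated concentration at all.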